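Methyl on the phenyl of compound 3

The compounds below may be only part of what the source reports. "The series", "measured", "known", "first", "only" and "open" are said of these compounds alone.

In a functional assay on PC-3 cells (Homo sapiens) for cytotoxicity (on this read-out lower numbers stand for an effect already at smaller amounts and higher numbers for an effect only at larger amounts of compound), compound 1 (`COC1=C(C)C(=O)/C(=C(O)/C=C/c2c(C)cccc2C)C(=O)C1(C)C`) gives 17.1 ug/mL, compound 2 (`C=Cc1ccccc1/C=C/C(O)=C1/C(=O)C(C)=C(OC)C(C)(C)C1=O`) gives 4.6 ug/mL and compound 3 (`CCC1=C(OC)C(CC)(CC)C(=O)C(C(=O)/C=C/c2ccccc2)=C1O`) gives 7.7 ug/mL. Compound 3 thus lies within the scatter of compound 2, while its number stands beyond the scatter below that of compound 1. Its core also differs from the core shared by the other two.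

Compound 4 (`CCC1=C(OC)C(CC)(CC)C(=O)C(C(=O)/C=C/c2ccc(C)cc2)=C1O`) is compound 3 with methyl in place of hydrogen on an aromatic carbon, para to a large group: methyl in place of hydrogen on an aromatic carbon.

Within the data shown here, only one measured step offers any guidance: a 3.7-fold lower number from compound 1 to compound 2 (0.57 log units; beyond the scatter). This modest step exchanges one substituted phenyl group for another on a different core, so it bears on the new change only loosely. Among the measured compounds shown here, no measured pair shows methyl in place of hydrogen on an aromatic carbon, and the direction of any shift remains open. With so little evidence, no step beyond the scatter is expected in this assay. The expected change is a 1.0-fold lower number from compound 3 to compound 4 (0.01 log units; within the scatter), a size estimated to stay within the scatter. For compound 4 the estimated value is 7.5 ug/mL, with an expected range from 3.5 ug/mL to 16 ug/mL.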

Compound 4, concentration for half-maximal effect: 15 ug/mL
For compound 4 the middle estimate is 2.0-fold (0.30 log units) below the measured one; measured number inside the range.
By their numbers in this assay, from the lowest: compounds 2, 3, 4 and 1 (each within the scatter of the next, the first and the last beyond it).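

In this assay, among these compounds, methyl in place of hydrogen on an aromatic carbon, para to a large group, gives a 1.9-fold higher number from compound 3 to compound 4 (0.29 log units; within the scatter); this is the first reading of any substituent at this position of the phenyl, and on the core of compound 3 the added methyl leaves the number within the scatter. Among the compounds shown here, the only earlier step, a 3.7-fold lower number from compound 1 to compound 2 (0.57 log units; beyond the scatter), lies beyond the scatter, but it exchanges one substituted phenyl for another on a different core, so the two steps describe different changes and do not combine into a trend. Nothing available explains the result of the methyl change, and no supporting measurement bears on it.

On these data alone, whether a group other than methyl at this place, such as methoxy, chlorine or a carboxylic acid, would produce a step beyond the scatter remains open, since one pair defines no trend for the phenyl to 4-methylphenyl change. Also open, as far as these compounds go, is whether the same methyl would read alike on the core shared by compound 1 and compound 2, where the two numbers stand well apart.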